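The compounds below may be only part of what the source reports. "The series", "measured", "known", "first", "only" and "open" are said of these compounds alone.

Measured compounds:
- compound 1 `O=C(CN(c1nc(Cl)nc2[nH]cnc12)C1CC1)N[C@@H](CO)C(=O)O`: in a functional assay on the whole organism (Tail, strain ICR) with Mus musculus as the target, in the tail flick test, with a stated time of 90 min, at a dose of 25 umol/kg by the oral route (on this read-out lower numbers stand for a weaker effect and higher numbers for a stronger effect at the one dose given), compound 1 gives 43.9%
- compound 2 `NC(=O)C[C@H](NC(=O)CN(c1nc(Cl)nc2[nH]cnc12)C1CC1)C(=O)O`: compound 2 gives 20.1%
- compound 3 `CSCC[C@H](NC(=O)CN(c1nc(Cl)nc2[nH]cnc12)C1CC1)C(=O)O`: compound 3 gives 14%

Compound 3 has the lowest of the three numbers in this assay; compound 2 sits within the scatter of it, while compound 1 lies beyond it, as a number 29.9 percentage points lower from compound 1 to compound 3 (beyond the scatter) shows. Compound 4 `C[C@H](NC(=O)CN(c1nc(Cl)nc2[nH]cnc12)C1CC1)C(=O)O` differs from compound 3 in one place: hydrogen in place of (methylsulfanyl)methyl on a saturated chain carbon, two bonds along the chain from an amide-type nitrogen and a carbonyl carbon. For the measured compounds named here, no measured step removes a group at that place entirely, so the nearest guides are a number 29.9 percentage points lower from compound 1 to compound 3 (beyond the scatter) and a number 6.1 percentage points lower from compound 2 to compound 3 (within the scatter). The first shows that compound 1, carrying hydroxy at that place, gave a clearly higher number; the second shows that exchanging carbamoyl for (methylsulfanyl)methyl changed little. A small rise is therefore expected for compound 4, a number 8 percentage points higher from compound 3 to compound 4 (within the scatter), likely within the scatter. Compound 4 is expected to give 22%, in the range 8% to 42%.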

Compound 4, a percentage reported as activity, at one dose (the size of the read-out at that dose, not a potency): 43.5%
For compound 4 the middle estimate is 21.5 percentage points below the measured one, and the stated range ends below it.
By their numbers in this assay, from the lowest: compounds 3 and 2 (each within the scatter of the next); then compounds 4 and 1 (each within the scatter of the next).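

At this saturated chain carbon in this assay hydrogen in place of (methylsulfanyl)methyl gives a number 29.5 percentage points higher from compound 3 to compound 4 (beyond the scatter) and hydrogen in place of carbamoyl gives a number 23.4 percentage points higher from compound 2 to compound 4 (beyond the scatter) in the same assay. Among these four compounds, a group at this carbon is thus not needed for the higher number, and the step of a number 0.4 percentage points lower from compound 1 to compound 4 (within the scatter) puts hydrogen level with hydroxy. Nothing available explains these differences. From the compounds shown here alone, whether an amine, a carboxylic acid or a longer carbon chain at this carbon would group with hydrogen and hydroxy, or with carbamoyl and (methylsulfanyl)methyl, remains open.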